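Notes on the step from compound 3 to compound 4

This account rests on a few compounds, and the source may have more. Where it says the series, first, only, none or still open, it means among the compounds named here.

Measured so far in a functional assay on Jurkat cells (Homo sapiens) for inhibition, read by CCK-8 assay, with a stated time of 48 h; on this read-out higher numbers stand for weaker inhibition of growth and lower numbers for stronger inhibition of growth:
- compound 1 `Cc1ccccc1Nc1nc(Nc2ccc(N3CCN(C)CC3)cn2)ncc1Cl`: 8080 nM
- compound 2 `CN1CCN(c2ccc(Nc3ncc(Cl)c(Nc4ccccc4)n3)nc2)CC1`: > 100000 nM (a limit)
- compound 3 `CN1CCN(c2ccc(Nc3ncc(Cl)c(NCc4ccco4)n3)nc2)CC1`: > 100000 nM (a limit)

Compound 3 sits at the limit of > 100000 nM in this assay, at which 2 of the 3 values shown sit, so no number is known for it. The next structure is compound 4 `CC(C)c1ccccc1Nc1nc(Nc2ccc(N3CCN(C)CC3)cn2)ncc1Cl`, with this change from compound 3: 2-isopropylphenyl in place of (furan-2-yl)methyl on a nitrogen on an aromatic ring. In words, 2-isopropylphenyl stands in place of (furan-2-yl)methyl on a nitrogen on an aromatic ring.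

For the measured compounds named here, two measured steps bear on this. One is an at least 12-fold higher number from compound 1 to compound 3 (1.09 log units; beyond the scatter), a large step at the same place, and the other is an at least 12-fold higher number from compound 1 to compound 2 (1.09 log units; beyond the scatter), equally large. Among the three measured compounds, only compound 1, which carries 2-methylphenyl, gives a number, 8080 nM. The expectation in this assay is therefore a large step to a lower number, about as large as those two steps read in reverse. The expected step is an at least 16-fold lower number from compound 3 to compound 4 (1.22 log units; beyond the scatter). For compound 4 the estimated value is 6000 nM, with an expected range of 1000 nM to 40000 nM.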

Compound 4, concentration for 50% growth inhibition: 5140 nM
Compound 4: middle estimate off by 1.2-fold (0.07 log units), on the high side; low and high end bracket the measured number.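

In this assay, compound 2 and compound 3 each stand at a limit and give no number: the limit of > 100000 nM in this assay, at which 2 of the 4 values shown sit.

Isopropyl on the aromatic carbon, like methyl in compound 1, gives a readable number where hydrogen gives none: the record shows an at least 19-fold lower number from compound 2 to compound 4 (1.28 log units; beyond the scatter) for that single change and an at least 19-fold lower number from compound 3 to compound 4 (1.28 log units; beyond the scatter) when 2-isopropylphenyl replaces (furan-2-yl)methyl on the nitrogen. Methyl and isopropyl cannot be told apart at this place, with a 1.6-fold lower number from compound 1 to compound 4 (0.20 log units; within the scatter) as the printed step, so enlarging the group from methyl to isopropyl shows no separate effect in this series.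

Going by these compounds, it remains open whether the number depends on an alkyl group at all or whether methoxy or chloro on the same aromatic carbon would also give a readable value. A larger group such as tert-butyl is also untested among the compounds shown, so the upper size limit at this place is unknown.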